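Piperazinyl amide variation on a fluorinated methylidene core

The source may hold more compounds than are shown below. What is called first, only, known or untested is meant among the compounds shown, and "the series" means these compounds.

Compound 1 `CC1=C(C(C)C(=O)N(CCNC(C)C)C(C)C)c2cc(F)ccc2/C1=C\c1ccc([S+](C)[O-])cc1` serves as the reference. In a functional assay on MDA-MB-231 cells (Homo sapiens) for inhibition, read by CellTiter-Glo, with a stated time of 96 h (on this read-out lower numbers stand for higher toxicity in this test and higher numbers for lower toxicity in this test), compound 1 gives 21300 nM. Compound 2 `CC1=C(C(C)C(=O)NCCN2CCCC2)c2cc(F)ccc2/C1=C\c1ccc([S+](C)[O-])cc1` gives 39300 nM in this assay, and the step of a 1.8-fold higher number from compound 1 to compound 2 (0.27 log units; within the scatter) lies within the scatter. Compound 3 `CC1=C(C(C)C(=O)N2CCN(CCCN(C)C)CC2)c2cc(F)ccc2/C1=C\c1ccc([S+](C)[O-])cc1` reaches only the limit > 50000 nM in this assay. That ceiling the limit of > 50000 nM in this assay, at which 1 of the 3 values shown sits, sets a floor under the step of an at least 2.3-fold higher number from compound 1 to compound 3 (0.37 log units; beyond the scatter), while the step of an at least 1.2-fold higher number from compound 2 to compound 3 (0.10 log units; that floor lies within the scatter) is less telling. Compound 4 `CC1=C(C(C)C(=O)N2CCN(c3ccncc3)CC2)c2cc(F)ccc2/C1=C\c1ccc([S+](C)[O-])cc1` carries 4-(pyridin-4-yl)piperazin-1-yl in place of isopropyl(2-(isopropylamino)ethyl)amino on a carbonyl carbon. The step toward compound 3 bears most closely on this change: compound 3 also carries a piperazin-1-yl group on the carbonyl carbon and returns only a limit. A higher number is therefore expected for compound 4, with an estimated step of a 2.1-fold higher number from compound 1 to compound 4 (0.32 log units; beyond the scatter). Compound 4 is estimated at 45000 nM, within 18000 nM to 110000 nM.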

Compound 4, half-maximal cytotoxic concentration: 19600 nM
Compound 4: the middle estimate sits 2.3-fold (0.36 log units) above what was measured; measured number inside the range.
By their numbers in this assay, from the lowest: compounds 4, 1 and 2 (each within the scatter of the next). At a limit, above all of these: compound 3.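

The piperazin-1-yl group on the carbonyl carbon does not alone set the number in this assay: with pyridin-4-yl in place of 3-(dimethylamino)propyl on an amine nitrogen in a ring, the outcome is an at least 2.5-fold lower number from compound 3 to compound 4 (0.40 log units; beyond the scatter). The other two amides give a 1.1-fold lower number from compound 1 to compound 4 (0.04 log units; within the scatter) and a 2.0-fold lower number from compound 2 to compound 4 (0.30 log units; within the scatter), so compound 4 cannot be told apart from compound 1 or compound 2. The step from compound 3 starts from a limit, not a number: the limit of > 50000 nM in this assay, at which 1 of the 4 values shown sits.

The compounds shown leave open whether a pyridin-3-yl or phenyl group on that ring nitrogen would match pyridin-4-yl, and whether a shorter aminoalkyl chain there would read like compound 3 or compound 4.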